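Diethylamino in place of dimethylamino on a propyl chain

The source may hold more compounds than are shown below. What is called first, only, known or untested is meant among the compounds shown, and "the series" means these compounds.

Among the compounds with values here, in an ADME assay on HEK293 cells (Homo sapiens) for cytotoxicity, read by MTT assay, with a stated time of 48 h (on this read-out higher numbers stand for weaker inhibition and lower numbers for stronger inhibition), compound 2 `CN(C)CCCn1c(N)c(-c2nc3cc(Cl)ccc3[nH]2)c2nc(C#N)c(C#N)nc21` gives 11700 nM, the only number so far. Compound 1 `CCN(CC)CCn1c(N)c(-c2nc3cc(Cl)ccc3[nH]2)c2nc(C#N)c(C#N)nc21` gives > 50000 nM, which is a limit of the assay and not a number. Compound 3 `CCN(CC)CCCn1c(N)c(-c2nc3cc(Cl)ccc3[nH]2)c2nc(C#N)c(C#N)nc21` is still to be measured. It differs from compound 2 in one place: diethylamino in place of dimethylamino on a saturated chain carbon, three bonds along the chain from an aromatic nitrogen. Within the data shown here, the one measured step that bears on this is an at least 4.2-fold lower number from compound 1 to compound 2 (0.63 log units; beyond the scatter). That step also alters the chain, so it matches the new change only in part, and it runs the opposite way, leaving diethylamino. A smaller move towards a higher number, meaning weaker inhibition, is expected in this assay, namely a 1.9-fold higher number from compound 2 to compound 3 (0.27 log units; within the scatter). Compound 3 is estimated at 22000 nM, with an expected range from 9000 nM to 50000 nM.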

Compound 3, half-maximal inhibitory concentration: 8420 nM
Beside the measured number, compound 3's estimate is 2.6-fold (0.42 log units) above it; measured number below the stated range.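

At this position, the three-carbon... 

Replacing 3-(dimethylamino)propyl with 3-(diethylamino)propyl gives a 1.4-fold lower number from compound 2 to compound 3 (0.14 log units; within the scatter), so in this assay this swap of the amine's groups has no readable effect. Holding diethylamino fixed isolates the chain, which the earlier step could not do because it changed the chain and the amine together: the change to the propyl chain gives an at least 5.9-fold lower number from compound 1 to compound 3 (0.77 log units; beyond the scatter). The value of compound 1 is a limit and not a number: the limit of > 50000 nM in this assay, at which 1 of the 3 values shown sits.

The compounds shown leave open how far this chain effect extends, since a chain longer than propyl would test whether the number keeps falling. A ring amine such as pyrrolidine or morpholine at the chain end would show whether the flat result holds beyond simple dialkylamino groups.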